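The compounds below may be only part of what the source reports. "The series", "measured", "known", "first", "only" and "open" are said of these compounds alone.

Compound 1, `COc1cc(/C=C2\Cc3ccccc3/C(=C\c3ccc([N+](=O)[O-])cc3)C2=O)ccc1O`, gives 950 nM in a functional assay on HL-60 cells (Homo sapiens) for cytotoxicity; on this read-out higher numbers stand for lower toxicity in this test and lower numbers for higher toxicity in this test.
Compound 2, `COc1ccc(/C=C2\Cc3ccccc3/C(=C\c3ccc([N+](=O)[O-])cc3)C2=O)cc1OC`, gives 560 nM in this assay.
Compound 3, `O=C1/C(=C/c2ccc(O)cc2)CCC/C1=C\c1ccc([N+](=O)[O-])cc1`, gives 4400 nM in this assay.

Compound 2 differs from compound 1 by one change, (methyl in place of hydrogen on an oxygen on an aromatic ring), and that change made a 1.7-fold lower number from compound 1 to compound 2 (0.23 log units; within the scatter). Compound 3 has the highest of the three numbers; the difference between its core and the core of compound 1 is not broken down here, and only the two values themselves show how far apart the two compounds stand.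

Compound 4, `COc1ccc(/C=C2\CCC/C(=C\c3ccc([N+](=O)[O-])cc3)C2=O)cc1`, has not yet been measured. Among the measured compounds shown here, it differs from compound 3 by methyl in place of hydrogen on an oxygen on an aromatic ring, the same change as the one from compound 1 to compound 2, in the same place, though read one bond further out it turns 4-hydroxyphenyl into 4-methoxyphenyl rather than 4-hydroxy-3-methoxyphenyl into 3,4-dimethoxyphenyl. For the measured compounds named here, on the strength of the single earlier step, compound 4 is expected to give about 2600 nM in this assay, with the range 1200 nM to 5500 nM. That estimate means a step of a 1.7-fold lower number from compound 3 to compound 4 (0.23 log units; within the scatter), expected to match the earlier step in size because of a 1.7-fold lower number from compound 1 to compound 2 (0.23 log units; within the scatter), which stayed within the scatter.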

Compound 4, half-maximal cytotoxic concentration: > 400000 nM
Compound 4 ended at the assay's limit; the forecaster's own chance of this, stated with the estimate: 5%; middle value at least 150-fold (2.18 log units) from the limit.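

In this assay compound 4 reads > 400000 nM, which is a limit of the assay and not a number. Methyl in place of hydrogen on the aromatic ring's oxygen gave an at least 90-fold higher number from compound 3 to compound 4 (1.95 log units; beyond the scatter), so the change did not carry over from the core of compound 1 to the core of compound 3 with the same size or direction: the same change on two cores in this assay, a 1.7-fold lower number (0.23 log units; within the scatter) from compound 1 to compound 2 and an at least 90-fold higher number (1.95 log units; beyond the scatter) from compound 3 to compound 4, at least 150-fold (2.18 log units) apart, beyond the scatter of two such steps This rests on a single pair on each core, and the true size of the new step stays unknown; the data also do not show why the two steps part, since compound 1 and compound 2 carry a further methoxy group that compound 3 and compound 4 lack, so the core cannot be separated from that group.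

The compounds shown leave open whether a longer chain on that oxygen, such as ethyl, would stay as close to compound 3 or as far from it as compound 4 does. They also leave open how an amine in place of the hydroxy would read on either core.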